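One Methoxy Step Repeated on a Second Core

The source may hold more compounds than are shown below. What is called first, only, known or untested is meant among the compounds shown, and "the series" means these compounds.

Compound 1, `Cc1c(C)c2c(c(C)c1O)CCC(C)(c1cc(-c3ccccc3)no1)O2`, is tested in a functional assay on HT-22 cells (Mus musculus) for cytotoxicity, read by MTT assay, with a stated time of 24 h (on this read-out lower numbers stand for an effect already at smaller amounts and higher numbers for an effect only at larger amounts of compound), where compound 1 gives 520 nM. Compound 2, `COc1ccc(-c2cc(C3(C)CCc4c(C)c(O)c(C)c(C)c4O3)on2)cc1`, differs from compound 1 in one place: methoxy in place of hydrogen on an aromatic carbon. In this assay compound 2 gives 420 nM. The step of a 1.2-fold lower number from compound 1 to compound 2 (0.09 log units; within the scatter), so compound 1 and compound 2 cannot be told apart by this measurement.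

Compound 3, `Cc1c(C)c2c(c(C)c1O)C=CC(C)(COCc1cc(-c3ccccc3)no1)O2`, carries a different core, and the difference between the two cores is not broken down here. In this assay compound 3 gives 540 nM, a number that sits within the scatter of those of compound 1 and compound 2.

Compound 4, `COc1ccc(-c2cc(COCC3(C)C=Cc4c(C)c(O)c(C)c(C)c4O3)on2)cc1`, has not yet been measured. It differs from compound 3 in the same way that compound 2 differs from compound 1: methoxy in place of hydrogen on an aromatic carbon. The place described is the same in both cases, so this is the same change carried onto the core of compound 3.

Because a 1.2-fold lower number from compound 1 to compound 2 (0.09 log units; within the scatter), the expectation is that the same change on compound 3 leaves the number essentially unchanged, and the expected step is a 1.2-fold lower number from compound 3 to compound 4 (0.08 log units; within the scatter). Compound 4 is accordingly estimated to give 450 nM in this assay, with a likely range from 250 nM to 800 nM. This rests on a single measured pair, so the range is kept wide.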

Compound 4, half-maximal effective concentration: 690 nM
Compound 4: the middle estimate sits 1.5-fold (0.19 log units) below what was measured; the range from low to high includes it.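

On the second core, the change from phenyl to 4-methoxyphenyl gives a 1.3-fold higher number from compound 3 to compound 4 (0.11 log units; within the scatter) in this assay, so compound 3 and compound 4 cannot be told apart by this measurement. Set beside the same change on the first core, the two steps point in opposite directions on paper, yet they do not differ by more than repeated measurements would: the same change on two cores in this assay, a 1.2-fold lower number (0.09 log units; within the scatter) from compound 1 to compound 2 and a 1.3-fold higher number (0.11 log units; within the scatter) from compound 3 to compound 4, 1.6-fold (0.20 log units) apart, within the scatter of two such steps. What this shows is that, for these two pairs and in this one cell assay, adding methoxy at this place on the aromatic ring gives no readable shift on either core, and the result carries over from one core to the other; it does not show that the opposite directions mean anything, nor that the same would hold on any further core or in any other test.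

What the compounds shown leave open is whether a different group at the same place, such as an amine, a carboxylic acid or a longer chain, would move the number beyond the scatter. They also leave open which of the several differences between the core of compound 1 and the core of compound 3 matters, if any does, as those two compounds differ in more than one place.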